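From 4-chloro-2-fluorophenyl to cycloheptyl on a ring nitrogen

The compounds below may be only part of what the source reports. "The series", "measured", "known", "first", "only" and "open" are said of these compounds alone.

Measured compounds:
- compound 1, `Nc1scc(CN2CCN(c3ccc(F)cc3Cl)CC2)c1C(=O)c1ccc(Cl)cc1`: 0%
- compound 2, `Nc1scc(CN2CCN(c3ccc(Cl)cc3F)CC2)c1C(=O)c1ccc(Cl)cc1`: 0%
- compound 3, `Nc1scc(CN2CCN(c3ccncc3)CC2)c1C(=O)c1ccc(Cl)cc1`: 1%

All three were tested in an assay on CHO cells for displacement of a labelled ligand from adenosine receptor A1 (Homo sapiens), read by scintillation counting, with a stated time of 120 min, tested at 10 uM; a lower number here means less inhibition, a higher number more inhibition at the concentration tested (going by the name of the read-out). Compound 2 stands level with compound 1, the two together being the lowest of the three numbers; the step of no change at the digits printed from compound 1 to compound 2 (within the scatter) lies within the scatter, and so does the step of a number 1 percentage points higher from compound 2 to compound 3 (within the scatter). In short, none of the three shows measurable inhibition.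

Compound 4, `Nc1scc(CN2CCN(C3CCCCCC3)CC2)c1C(=O)c1ccc(Cl)cc1`, is not yet measured. It differs from compound 2 in one place: cycloheptyl in place of 4-chloro-2-fluorophenyl on an amine nitrogen in a ring

Both measured steps change the group on the same ring nitrogen, and both were flat: no change at the digits printed from compound 1 to compound 2 (within the scatter) and a number 1 percentage points higher from compound 2 to compound 3 (within the scatter). Going by the values given here, no measured step replaces an aromatic ring there with a non-aromatic one, so the new change has no direct precedent. Since every measured variation at that position left the read-out near zero, the expectation for compound 4 is again a step no larger than the scatter, a number 3 percentage points higher from compound 2 to compound 4 (within the scatter). Compound 4 is therefore estimated at 3%, within a range from -5% to 15%.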

Compound 4, a percentage reported as inhibition, at one concentration (the size of the read-out at that concentration, not a potency): 0%
For compound 4 the middle estimate is 3 percentage points above the measured one; the measured number falls inside the stated range.
By their numbers in this assay, from the lowest: compounds 1, 2, 4 and 3 (each within the scatter of the next).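

In this assay, cycloheptyl is the only non-aromatic ring among the four compounds at this ring nitrogen, and it leaves the read-out where the aromatic groups left it (no change at the digits printed from compound 2 to compound 4 (within the scatter); no change at the digits printed from compound 1 to compound 4 (within the scatter); a number 1 percentage points lower from compound 3 to compound 4 (within the scatter)). The flat picture at this position therefore now covers a seven-membered ring of carbon only, as well as the halogenated phenyl rings and the pyridin-4-yl ring. Nothing available explains why the read-out stays flat here.

With all four compounds this close together, the data cannot rank these groups or show which feature of the group at this nitrogen, if any, matters. On these data alone, it remains open whether a carboxylic acid, a primary amine or a longer alkyl chain on this nitrogen would give measurable inhibition, or whether a change elsewhere on the shared core would.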